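Guanidine to amine on a fluorophenyl ether series

The compounds below may be only part of what the source reports. "The series", "measured", "known", "first", "only" and "open" are said of these compounds alone.

Measured compounds:
compound 1 `NCCCOc1ccc(CNc2nc3ccc(Oc4ccc(O)cc4)cc3s2)cc1` gives 205000 nM in an assay on SH-SY5Y cells for inhibition of Voltage-dependent N-type calcium channel subunit alpha-1B (Homo sapiens), read by FLIPR and calcium flux, with stated times of 600 s and 300 s, in the presence of a further agent that is not named here; on this read-out lower numbers stand for stronger inhibition and higher numbers for weaker inhibition;
compound 2 `NCCCOc1ccc(CNc2nc3ccc(Oc4ccc(C(F)(F)F)cc4)cc3s2)cc1` gives 59000 nM in this assay;
compound 3 `N=C(N)NCCCOc1ccc(CNc2nc3ccc(Oc4ccc(F)cc4)cc3s2)cc1` gives 244000 nM in this assay.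

Compound 3 stands with the highest number of the three. Compound 1 sits within the scatter of compound 3, while compound 2 lies beyond it with a lower number. Going by the values given here, the only step that can be computed between measured compounds is a 3.5-fold lower number from compound 1 to compound 2 (0.54 log units; beyond the scatter), a change on an aromatic carbon that leaves the side chain untouched.

Compound 4 `NCCCOc1ccc(CNc2nc3ccc(Oc4ccc(F)cc4)cc3s2)cc1` differs from compound 3 in a single place: a hydrogen atom in place of a group of 3 heavy atoms (1 carbon, 2 nitrogen; no ring), on an amine nitrogen. Among the compounds with values here, no measured pair shows this change, so nothing in these three values tells how much the chain ending matters here. Compound 4 shares its amine chain with compound 1 and compound 2, and its fluorophenyl ether with compound 3; the gap between compound 1 and compound 2 shows only that the aromatic substituent moves the number by a modest amount.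

Within the data shown here, with no bearing step, compound 4 is expected to land close to compound 3, a step of a 1.5-fold lower number from compound 3 to compound 4 (0.18 log units; within the scatter) that is not expected to exceed the scatter. The estimate for compound 4 is 160000 nM, with a range from 60000 nM to 400000 nM.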

Compound 4, half-maximal inhibitory concentration: 106000 nM
Beside the measured number, compound 4's estimate is 1.5-fold (0.18 log units) above it, within the range that was stated.
By their numbers in this assay, from the lowest: compounds 2, 4, 1 and 3 (each within the scatter of the next, the first and the last beyond it).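

In this assay, going by these compounds alone, a hydrogen atom in place of the group of 3 heavy atoms on the amine nitrogen gives a 2.3-fold lower number from compound 3 to compound 4 (0.36 log units; beyond the scatter), the first measured pair for this change, which shows that the chain ending does move the number, though only modestly, with the fluorophenyl ether held fixed. With the amine chain held fixed, fluoro in place of trifluoromethyl gives a 1.8-fold higher number from compound 2 to compound 4 (0.25 log units; within the scatter) and fluoro in place of hydroxy gives a 1.9-fold lower number from compound 1 to compound 4 (0.29 log units; within the scatter), so compound 4 cannot be told apart from either of these two compounds, even though they stand apart from each other. Of the three new steps, only the change at the amine nitrogen lies beyond the scatter, and nothing shown here accounts for its size or direction.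

Going by these compounds, whether the same step holds with trifluoromethyl or hydroxy on the aromatic carbon stays open, since the pair exists only for the fluoro compounds. Also open, on these data alone, is how other endings on the amine nitrogen, such as a methyl group, an acetyl group or a longer chain, would compare in this assay.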